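Trimethoxyphenyl chromene series: an acetyl analogue to be measured

This account rests on a few compounds, and the source may have more. Where it says the series, first, only, none or still open, it means among the compounds named here.

Compound 1, `CCCCNC(=O)C1=Cc2ccc(OC)cc2OC1c1cc(OC)c(OC)c(OC)c1`, gives 25500 nM in a functional assay for inhibition of nuclear factor NF-kappa-B complex (Homo sapiens); a higher number here means a weaker inhibitor, a lower number a stronger inhibitor.
Compound 2, `COc1ccc2c(c1)OC(c1cc(OC)c(OC)c(OC)c1)C(/C=N/O)=C2`, gives 14100 nM in this assay.
Compound 3, `COc1ccc2c(c1)OC(c1cc(OC)c(OC)c(OC)c1)C(C(=O)OC(C)(C)C)=C2`, gives 14100 nM in this assay.

Compound 3 stands level with compound 2 at the digits shown, and the two share the lowest numbers of the three; its only other neighbour is compound 1, and that step, a 1.8-fold lower number from compound 1 to compound 3 (0.26 log units; within the scatter), lies within the scatter. Compound 4, `COc1ccc2c(c1)OC(c1cc(OC)c(OC)c(OC)c1)C(C(C)=O)=C2`, differs from compound 3 at the carbonyl carbon: methyl in place of tert-butoxy on a carbonyl carbon, which cut one bond further out reads tert-butoxycarbonyl to acetyl. Among the compounds with values here, two measured steps touch the same position. The exchange of butylamino for tert-butoxy gave a 1.8-fold lower number from compound 1 to compound 3 (0.26 log units; within the scatter), and the exchange of the oxime-type group for tert-butoxycarbonyl gave no change at the digits printed from compound 2 to compound 3 (within the scatter); neither moved the number beyond the scatter. On that basis the change to methyl is expected to leave this assay essentially where compound 3 sits, with no step beyond the scatter in either direction. Compound 4 is therefore estimated at 15000 nM, with a plausible range from 6000 nM to 40000 nM. The expected step is a 1.1-fold higher number from compound 3 to compound 4 (0.03 log units; within the scatter).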

Compound 4, half-maximal inhibitory concentration: 14100 nM
For compound 4 the middle estimate is 1.1-fold (0.03 log units) above the measured one; the range from low to high includes it.
By their numbers in this assay, from the lowest: compounds 2, 3, 4 and 1 (each within the scatter of the next).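

In this assay the exchange of tert-butoxy for methyl on a carbonyl carbon, which removes its hydrogen-bond acceptor, gives no change at the digits printed from compound 3 to compound 4 (within the scatter) and so shows that tert-butoxy is not needed to hold the number where it stands. Within the data shown here, the acetyl group also matches the oxime-type group on the double-bonded ring carbon, with no change at the digits printed from compound 2 to compound 4 (within the scatter) in that comparison, while replacing butylamino with methyl gives a 1.8-fold lower number from compound 1 to compound 4 (0.26 log units; within the scatter) and thus extends the flat picture to a fourth group, with no compound among the four going against it. The data shown offer no explanation for this lack of response.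

On these data alone, it remains open whether any group at this position can move the number beyond the scatter, for instance a carboxylic acid, a primary amine or a longer alkyl chain on the carbonyl carbon. As far as these compounds go, it also remains open whether the same flat response would hold with the methoxy groups of the shared core replaced by hydroxy groups.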